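This account rests on a few compounds, and the source may have more. Where it says the series, first, only, none or still open, it means among the compounds named here.

Measured so far:
Compound 1, `Cc1cccc(NC(=O)N[C@H](C)c2ccccc2)c1`: in an ADME assay on the whole organism with Oryza sativa as the target, tested at 10 uM (a higher number here means a weaker effect of the compound at the concentration tested, a lower number a stronger effect), compound 1 gives 47%.
Compound 2, `C[C@@H](NC(=O)Nc1cccc(Cl)c1)c1ccccc1`: in this assay compound 2 gives 83%.

Among the measured compounds shown here, compound 2 stands highest of the two numbers; its only neighbour is compound 1, and the step between them is a number 36 percentage points higher from compound 1 to compound 2 (beyond the scatter), brought about by chloro in place of methyl on an aromatic carbon. Compound 3, `C[C@@H](NC(=O)Nc1cc(Cl)cc(Cl)c1)c1ccccc1`, has not yet been measured. It differs from compound 2 by chloro in place of hydrogen on an aromatic carbon. For the measured compounds named here, only one measured step bears on this change, the one from compound 1 to compound 2, and that step was large; yet it concerns a chloro replacing a methyl rather than a hydrogen, so it guides only loosely. A further chloro is expected to move this assay upward by a modest amount at most, since compound 2 already gives 83% and the percentage has little room left. The estimated step is a number 5 percentage points higher from compound 2 to compound 3 (within the scatter). Compound 3 is expected to give 88%, within a range of 70% to 100%.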

Compound 3, a percentage reported as activity, at one concentration (the size of the read-out at that concentration, not a potency): 99%
The estimate for compound 3 lay 11 percentage points below the measured number, within the range that was stated.
By their numbers in this assay, from the lowest: compound 1; then compound 2; then compound 3.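

In this assay, the step of a number 16 percentage points higher from compound 2 to compound 3 (beyond the scatter) shows that a chloro placed on an aromatic carbon that carried only hydrogen, meta to a chloro group, also weakens the effect of the compound at the concentration tested. The earlier step, a number 36 percentage points higher from compound 1 to compound 2 (beyond the scatter), exchanged a methyl for a chloro, so it could not show what adding a chloro in place of hydrogen does on its own. Nothing in the data explains why the number rises with either change.

The compounds shown leave open whether this rise is specific to chloro or would also follow from other groups at this place, such as fluoro, methoxy or an amine. Going by these compounds, it also remains open how a lone chloro at this place would behave, with hydrogen in place of the first chloro.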